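The source may report more compounds than this note shows. Statements on the series, on what has been measured and on what is new or still open speak of the compounds shown alone.

Compound 3, `CN1CCN(c2ccc(Nc3nc(-c4cccc(NC(=O)c5cccc(F)c5)c4)sc3C(N)=O)cc2)CC1`, is the lowest of the three measured compounds in a functional assay on Ramos cells (Homo sapiens) for antiproliferative activity, read by CCK-8 assay, with a stated time of 72 h, tested at 40 uM; on this read-out lower numbers stand for less inhibition and higher numbers for more inhibition at the one concentration tested (going by the name of the read-out): compound 3 gives 16.2%. Compound 2, `CN1CCN(c2ccc(Nc3nc(-c4cccc(NC(=O)c5ccc(F)cc5)c4)sc3C(N)=O)cc2)CC1`, gives 95.9%, and compound 1, `CCOC(=O)c1sc(-c2cccc(NC(=O)c3ccc(F)c(Cl)c3)c2)nc1Nc1ccc(N2CCN(C)CC2)cc1`, gives 72.5%. Among the compounds with values here, the one measured step that changes the same part of the molecule is a number 79.7 percentage points lower from compound 2 to compound 3 (beyond the scatter), a large drop beyond the scatter.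

Compound 4, `CN1CCN(c2ccc(Nc3nc(-c4cccc(NC(=O)c5ccc(F)c(Cl)c5)c4)sc3C(N)=O)cc2)CC1`, differs from compound 3 in exactly that part: 3-chloro-4-fluorophenyl in place of 3-fluorophenyl on a carbonyl carbon. Within the data shown here, this move in effect brings back the fluorine of compound 2 and adds a chlorine on the 3-chloro-4-fluorophenyl, the same group carried on the carbonyl carbon of compound 1, whose core differs from that of compound 4 only in the ester in place of the primary amide; no step between compound 1 and compound 4 is on record, so only the two values can be set side by side. Since compound 2 showed 95.9% and compound 1 showed 72.5%, a large rise from compound 3 is expected. The estimated step is a number 63.8 percentage points higher from compound 3 to compound 4 (beyond the scatter). Compound 4 is therefore expected to give about 80% in this assay, within a range of 45% to 98%.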

Compound 4, a percentage reported as inhibition, at one concentration (the size of the read-out at that concentration, not a potency): 97.5%
The estimate for compound 4 lay 17.5 percentage points below the measured number; measured number inside the range.
By their numbers in this assay, from the lowest: compound 3; then compound 1; then compounds 2 and 4 (each within the scatter of the next).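

In this assay, 3-chloro-4-fluorophenyl in place of 3-fluorophenyl on a carbonyl carbon gives a number 81.3 percentage points higher from compound 3 to compound 4 (beyond the scatter) and so reverses the drop seen with the 3-fluorophenyl group, while chloro in place of hydrogen on an aromatic carbon gives a number 1.6 percentage points higher from compound 2 to compound 4 (within the scatter) and so adds nothing this read-out can separate from the 4-fluorophenyl group alone. Among these compounds, the three with a fluorine as in the 4-fluorophenyl or 3-chloro-4-fluorophenyl groups all stand clearly above compound 3, and none goes against this, though compound 3 is the only one with the 3-fluorophenyl group. The other end of the molecule now also has a measured step, since amino in place of ethoxy on a carbonyl carbon gives a number 25 percentage points higher from compound 1 to compound 4 (beyond the scatter) with the 3-chloro-4-fluorophenyl group held constant.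

Going by these compounds, whether a 4-chlorophenyl or 4-methoxyphenyl group on the same carbonyl carbon, or a carboxylic acid in place of the primary amide, would hold this level remains open, and a reading at one concentration cannot rank compound 2 and compound 4 by potency. What lies behind these differences also stays open, as nothing shown here bears on it.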